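Notes on the amide substituent in a weakly cytotoxic series

A few compounds are considered here, and "the series" means these few. Any claim that something is new, unique, unknown or untested is made for them only; others in the source may bear on it.

Compound 1 `N#Cc1ccc(NC(=O)CN2C(=O)/C(=C/c3ccc(-c4ccc(Cl)cc4)o3)SC2=S)cc1` and compound 2 `O=C(CN1C(=O)/C(=C/c2ccc(-c3ccc(Cl)cc3)o2)SC1=S)NCc1ccccc1Cl` share one core and differ only at the amide-type nitrogen. In a functional assay on K562 cells (Homo sapiens) for cytotoxicity, read by MTT assay, with a stated time of 72 h (on this read-out higher numbers stand for weaker inhibition and lower numbers for stronger inhibition), compound 1 gives 85000 nM, and compound 2 gives 64000 nM. Among the measured compounds shown here, the step of a 1.3-fold lower number from compound 1 to compound 2 (0.12 log units; within the scatter) lies within the scatter, so compound 2 sits next to compound 1, the only other measured number, without being set apart from it. Compound 3 `CCCNC(=O)CN1C(=O)/C(=C/c2ccc(-c3ccc(Cl)cc3)o2)SC1=S` is not yet measured; it differs from compound 2 by ethyl in place of 2-chlorophenyl on a saturated chain carbon bound to an amide-type nitrogen. For the measured compounds named here, the only measured step at this position, from compound 1 to compound 2, is within the scatter, and no measured step covers the loss of the aromatic ring. For compound 3 the expectation in this assay is therefore no step beyond the scatter, if anything a somewhat higher number, estimated as a 1.4-fold higher number from compound 2 to compound 3 (0.15 log units; within the scatter). Compound 3 is expected to give 90000 nM, within a range from 35000 nM to 230000 nM.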

Compound 3, half-maximal inhibitory concentration: 50000 nM
Estimate against measurement, compound 3: 1.8-fold (0.26 log units) above; the measured number falls inside the stated range.
By their numbers in this assay, from the lowest: compounds 3, 2 and 1 (each within the scatter of the next).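

In this assay, taking the aromatic ring out of this position, with ethyl in place of 2-chlorophenyl on a saturated chain carbon bound to an amide-type nitrogen, gives a 1.3-fold lower number from compound 2 to compound 3 (0.11 log units; within the scatter), so the read-out does not depend on that ring at this level. Propyl in place of 4-cyanophenyl on an amide-type nitrogen reads the same way, with a 1.7-fold lower number from compound 1 to compound 3 (0.23 log units; within the scatter), which leaves an open chain and two different aromatic groups all within the scatter of one another at this position. Nothing measured beyond these numbers bears on the result.

Going by these compounds, whether any group at this nitrogen can move the number beyond the scatter stays open. The compounds shown say nothing about an amine or a carboxylic acid at the end of the chain, or about a chain longer than propyl.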